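A few compounds are considered here, and "the series" means these few. Any claim that something is new, unique, unknown or untested is made for them only; others in the source may bear on it.

Working notes on the series. Among the measured compounds shown here, compound 1 `CCCS(=O)(=O)NCCOc1nc(C2CC2)nc(NS(=O)(=O)c2ccc(C(C)C)cn2)c1Oc1ccccc1OC` and compound 2 `CCS(=O)(=O)NCCCOc1nc(C2CC2)nc(NS(=O)(=O)c2ccc(C(C)(C)C)cc2)c1Oc1ccccc1OC` share a common core and differ from each other at more than one place, so no single-point step between measured compounds is available. In a functional assay for inhibition of Endothelin-1 receptor (Rattus norvegicus) (a higher number here means weaker binding, a lower number tighter binding), compound 1 gives 288 nM. In this assay compound 2 gives 302 nM; the gap between compound 2 and compound 1 lies within the usual scatter, so on these two numbers compound 2 stands alongside compound 1 and the pair cannot be separated.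

Compound 3 `CCS(=O)(=O)NCCCOc1nc(C2CC2)nc(NS(=O)(=O)c2ccc(C(C)C)cn2)c1Oc1ccccc1OC` is the compound awaiting measurement. Relative to compound 2 the change is 5-isopropylpyridin-2-yl in place of 4-(tert-butyl)phenyl on a sulfonyl sulfur. For the measured compounds named here, the group entering is the one already carried by compound 1, while the remainder of compound 3 is that of compound 2. With compound 1 and compound 2 indistinguishable in this assay, the data give no reason to expect a shift in either direction, and the step from compound 2 to compound 3 is estimated at a 1.0-fold lower number from compound 2 to compound 3 (0.02 log units; within the scatter), not beyond the scatter. For compound 3 the expected value in this assay is 290 nM, with a range from 120 nM to 700 nM.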

Compound 3, dissociation constant: 105 nM
The estimate for compound 3 lay 2.8-fold (0.44 log units) above the measured number; measured number below the stated range.
By their numbers in this assay, from the lowest: compound 3; then compounds 1 and 2 (each within the scatter of the next).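

In this assay, with the rest of compound 2 held, 5-isopropylpyridin-2-yl in place of 4-(tert-butyl)phenyl on a sulfonyl sulfur gives a 2.9-fold lower number from compound 2 to compound 3 (0.46 log units; beyond the scatter) and so shows that the number responds to this place. At the other place, ((ethylsulfonyl)amino)methyl in place of (propylsulfonyl)amino on a saturated chain carbon gives a 2.7-fold lower number from compound 1 to compound 3 (0.44 log units; beyond the scatter) and moves the number in the same direction. Compound 1 and compound 2 differ at more than one place, so their pair could show neither single change, and no supporting measurement here accounts for either step.

The compounds shown leave open whether the step at the sulfonyl sulfur follows the ring nitrogen or the isopropyl group in place of tert-butyl, since a phenyl ring carrying isopropyl or a pyridine ring carrying tert-butyl would be needed to separate the two. They also leave open how the number behaves with other groups at the chain, such as a butylsulfonyl group or a carboxylic acid in place of the ethylsulfonyl group.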